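Swapping carboxy for methanesulfonamido on a shared core

This account rests on a few compounds, and the source may have more. Where it says the series, first, only, none or still open, it means among the compounds named here.

Compound 1 `COc1ccc2c(ccn2-c2ccc(O[C@H]3O[C@H](CO)[C@@H](O)[C@H](O)[C@@H]3O)c(Cl)c2)c1` gives 3 
Compound 2 `COC(=O)c1ccc2c(ccn2-c2ccc(O[C@H]3O[C@H](CO)[C@@H](O)[C@H](O)[C@@H]3O)c(Cl)c2)c1` gives 2.8 
Compound 3 `O=C(O)c1ccc2c(ccn2-c2ccc(O[C@H]3O[C@H](CO)[C@@H](O)[C@H](O)[C@@H]3O)c(Cl)c2)c1` gives 1.1 

In a physicochemical assay for lipophilicity, using the shake flask method, in phosphate buffer, measured as octanol-water partition, with a stated time of 2 h, at pH 7.4, tested at 1 uM (on this read-out lower numbers stand for lower lipophilicity and higher numbers for higher lipophilicity), compound 3 gives 1.1. It stands lowest of the three, beyond the scatter of both others. Compound 4 `CS(=O)(=O)Nc1ccc2c(ccn2-c2ccc(O[C@H]3O[C@H](CO)[C@@H](O)[C@H](O)[C@@H]3O)c(Cl)c2)c1` carries methanesulfonamido in place of carboxy on an aromatic carbon. Two measured steps replace another group with carboxy (a number 1.90 log units lower from compound 1 to compound 3 (beyond the scatter) and a number 1.70 log units lower from compound 2 to compound 3 (beyond the scatter)), and both are large. Methoxy and methoxycarbonyl, the groups in those starting compounds, hardly separate (a number 0.20 log units lower from compound 1 to compound 2 (within the scatter)). Going by the values given here, no measured compound carries methanesulfonamido, so these steps can only guide the direction and rough size. A clear rise in this assay is expected once carboxy leaves, though perhaps a smaller one than those two steps. The expected change is a number 1.30 log units higher from compound 3 to compound 4 (beyond the scatter) (an estimate, not a measurement). Compound 4 is estimated at 2.4 (expected range 1.8 to 2.9).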

Compound 4, distribution coefficient: 1.8
Compound 4: the middle estimate sits 0.60 log units above what was measured; the measured number falls inside the stated range.
By their numbers in this assay, from the lowest: compound 3; then compound 4; then compounds 2 and 1 (each within the scatter of the next).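

In this assay, putting methanesulfonamido at this aromatic carbon gives back only part of the drop seen with carboxy, with a number 0.70 log units higher from compound 3 to compound 4 (beyond the scatter). The number still falls short of the two other groups at this place, with a number 1.00 log units lower from compound 2 to compound 4 (beyond the scatter) and a number 1.20 log units lower from compound 1 to compound 4 (beyond the scatter), so the four compounds form three levels: carboxy lowest, methanesulfonamido in the middle, and methoxy and methoxycarbonyl together at the top. No measurement shown here explains why methanesulfonamido lands at this middle level.

Where an amine or a primary amide would fall at this aromatic carbon remains open, as does whether a longer chain such as ethanesulfonamido would stay close to compound 4. Whether these three levels would hold on a different core is also unknown.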